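From Azetidin-1-yl to (3-Fluorophenyl)amino on a Shared Core

The source may report more compounds than this note shows. Statements on the series, on what has been measured and on what is new or still open speak of the compounds shown alone.

Compound 3 `O=C1C(N2CCC2)=CC(=O)c2c1nc1n2[C@H]2OC[C@@H](O)[C@H]2OC1` carries an azetidin-1-yl group on the shared core. In a functional assay on HeLa cells (Homo sapiens) for inhibition, read by sulforhodamine B assay (a higher number here means a weaker inhibitor, a lower number a stronger inhibitor), compound 3 gives only a limit of the assay, > 16000 nM. Compound 1 `O=C1C(Nc2ccccc2)=CC(=O)c2c1nc1n2[C@H]2OC[C@@H](O)[C@H]2OC1` carries an anilino group in the same place. In this assay compound 1 likewise gives only a limit, > 8000 nM. The step from compound 1 to compound 3 is thus a step that the two limits leave unreadable from compound 1 to compound 3. Compound 2 `O=C1C=C(Nc2cccc(F)c2)C(=O)c2c1nc1n2[C@H]2OC[C@@H](O)[C@H]2OC1` carries a (3-fluorophenyl)amino group on the other double-bonded ring carbon, and in this assay compound 2 gives 6440 nM.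

Compound 4 `O=C1C(Nc2cccc(F)c2)=CC(=O)c2c1nc1n2[C@H]2OC[C@@H](O)[C@H]2OC1` is not yet measured. The change is (3-fluorophenyl)amino in place of azetidin-1-yl on a double-bonded ring carbon. Going by the values given here, no measured step matches this change directly; the one measured step runs between the two limits the limit of > 16000 nM in this assay, at which 1 of the 3 values shown sits, and the limit of > 8000 nM in this assay, at which 1 of the 3 values shown sits, and has no readable size. The values do show that compound 1 reaches only a limit, while compound 2, with the same (3-fluorophenyl)amino group on the other double-bonded ring carbon, gives a weak number. Compound 4 is therefore expected to remain weak, with an expected step of an at least 1.6-fold lower number from compound 3 to compound 4 (0.20 log units; that floor lies within the scatter) that cannot be read as more than scatter. The estimate for compound 4 is 10000 nM, with a range from 4000 nM to 30000 nM.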

Compound 4, half-maximal inhibitory concentration: > 8000 nM
Compound 4: no number, only a limit; the forecaster's own chance of this, stated with the estimate: 50%; the middle value does not contradict the limit.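

In this assay compound 4 gives only a limit, > 8000 nM. No new step can be read, since the steps from compound 3 and from compound 1 to compound 4 both end in limits. The compounds shown leave open how far fluoro in place of hydrogen, or (3-fluorophenyl)amino in place of azetidin-1-yl, changes the inhibition.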